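The source may report more compounds than this note shows. Statements on the series, on what has been measured and on what is new or still open speak of the compounds shown alone.

Working notes on the series. All three measured compounds share the core of compound 1 `CC1=C(/C=C/C(=O)/C=C/c2ccccc2)C(C)(C)CCC1` and were tested in a functional assay on IMR-32 cells (Homo sapiens) for cytotoxicity, read by sulforhodamine B assay, with a stated time of 48 h (on this read-out lower numbers stand for stronger inhibition and higher numbers for weaker inhibition), where compound 1 gives 20400 nM. Compound 2 `CC1=C(/C=C/C(=O)/C=C/c2ccc(Cl)cc2)C(C)(C)CCC1` gives 52300 nM. Among the compounds with values here, compound 3 `CC1=C(/C=C/C(=O)/C=C/c2ccccc2F)C(C)(C)CCC1` gives 15600 nM, the lowest of the three numbers so far; the step of a 1.3-fold lower number from compound 1 to compound 3 (0.12 log units; within the scatter) is within the scatter, whereas a 3.4-fold lower number from compound 2 to compound 3 (0.53 log units; beyond the scatter) lies beyond it, so compound 3 is separated only from compound 2. Compound 4 `CC1=C(/C=C/C(=O)/C=C/c2ccoc2)C(C)(C)CCC1` differs from compound 3 by furan-3-yl in place of 2-fluorophenyl on a double-bonded chain carbon bound to a double-bonded chain carbon. Within the data shown here, no measured step exchanges the six-membered aromatic ring for a five-membered one; the closest comparisons are the substituent changes a 2.6-fold higher number from compound 1 to compound 2 (0.41 log units; beyond the scatter) and a 1.3-fold lower number from compound 1 to compound 3 (0.12 log units; within the scatter) and the ring swap a 3.4-fold lower number from compound 2 to compound 3 (0.53 log units; beyond the scatter), all modest or within the scatter. Compound 4 is therefore expected to land near the existing numbers, with a step of a 1.4-fold higher number from compound 3 to compound 4 (0.15 log units; within the scatter) in this assay that is not expected to clear the scatter with confidence. The estimate for compound 4 is 22000 nM, range 8000 nM to 60000 nM.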

Compound 4, half-maximal inhibitory concentration: 56800 nM
Compound 4: middle estimate off by 2.6-fold (0.41 log units), on the low side; measured number inside the range.
By their numbers in this assay, from the lowest: compounds 3 and 1 (each within the scatter of the next); then compounds 2 and 4 (each within the scatter of the next).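

In this assay, within the data shown here, furan-3-yl is the first group on this double-bonded chain carbon that is not a six-membered aromatic ring of carbon only, and the change separates compound 4 from the two compounds without a chloro group, with a 3.6-fold higher number from compound 3 to compound 4 (0.56 log units; beyond the scatter) and a 2.8-fold higher number from compound 1 to compound 4 (0.44 log units; beyond the scatter). The exchange is not separated from the 4-chlorophenyl group, with a 1.1-fold higher number from compound 2 to compound 4 (0.04 log units; within the scatter), so a change of aromatic ring at this place can give a number that a single chloro substituent on phenyl also gives, and the higher number is not unique to the five-membered ring. Nothing available here accounts for these differences.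

The compounds shown leave open whether a thiophen-3-yl or a pyridin-3-yl ring at this place would stand with compound 4 or with compound 1. They also leave open how an amine or a carboxylic acid on the phenyl ring would shift the number.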